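The compounds below may be only part of what the source reports. "The series", "measured", "known", "first", "only" and "open" are said of these compounds alone.

In a functional assay on MCF7 cells (Homo sapiens) for antiproliferative activity, read by sulforhodamine B assay, with a stated time of 72 h (on this read-out lower numbers stand for stronger inhibition and higher numbers for weaker inhibition), compound 1 (`Fc1ccc(/C=C/c2cc3ccccc3nc2Cl)cc1`) gives 15100 nM and compound 2 (`COc1ccc2nc(Cl)c(/C=C\c3ccc(F)cc3)cc2c1`) gives 8970 nM, two values that lie within the usual scatter of each other. Compound 3 (`COc1ccc2nc(Cl)c(/C=C/c3ccc(F)cc3)cc2c1`) has the same atoms and bonds as compound 2 and differs only in configuration as drawn: the two compounds have the same atoms and bonds and differ only in configuration as drawn: 1 of 1 stereo elements differ; a double bond is drawn Z in compound 2 and E in compound 3. Among the measured compounds shown here, no measured pair of compounds shows the effect of this change alone, so nothing beyond the scatter is expected in this assay. The estimated step of a 1.2-fold higher number from compound 2 to compound 3 (0.09 log units; within the scatter) stays within that scatter. Compound 3 is expected at 11000 nM, with an estimated range of 4500 nM to 27000 nM.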

Compound 3, half-maximal inhibitory concentration: 14100 nM
Beside the measured number, compound 3's estimate is 1.3-fold (0.11 log units) below it; the measured number falls inside the stated range.
By their numbers in this assay, from the lowest: compounds 2, 3 and 1 (each within the scatter of the next).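

In this assay, the comparison of the two double-bond configurations gives a 1.6-fold higher number from compound 2 to compound 3 (0.20 log units; within the scatter), so this change does not separate the two compounds. Methoxy in place of hydrogen on an aromatic carbon gives a 1.1-fold lower number from compound 1 to compound 3 (0.03 log units; within the scatter), so on the E compounds this change does not separate them either. The configuration comparison is a clean one for a single reason: the fact that compounds 2 and 3 differ only in the configuration as drawn

The compounds shown leave open whether an amine or a hydroxyl group in place of the methoxy would give a step beyond the scatter. They also leave open whether the configuration change would read the same without the methoxy.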